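The source may report more compounds than this note shows. Statements on the series, on what has been measured and on what is new or still open speak of the compounds shown alone.

Measured so far:

Compound 1, `c1ccc(CNc2nnc(-c3ccc4cnccc4c3)o2)cc1`: 120 mL.min-1.g-1
Compound 2, `Fc1cc2cc(-c3nnc(NCc4ccccc4)o3)ccc2cn1`: 49 mL.min-1.g-1
Compound 3, `Fc1ncccc1[C@H](Nc1nnc(-c2c[nH]c3ncccc23)o1)C1CC1`: 21 mL.min-1.g-1

The read-out throughout is an ADME assay (liver) for metabolic stability, with Liver microsome (Homo sapiens) as the target, using microsomes; on this read-out higher numbers stand for fast clearance and lower numbers for slow clearance. In this assay compound 1 gives 120 mL.min-1.g-1 and compound 2 gives 49 mL.min-1.g-1. The two compounds differ in one place only, by fluoro in place of hydrogen on an aromatic carbon, and this change brings a 2.4-fold lower number from compound 1 to compound 2 (0.39 log units; beyond the scatter). Compound 3, with 21 mL.min-1.g-1, has the lowest number of the three, and its distance from both compound 1 and compound 2 lies beyond the usual scatter. How the core of compound 3 differs from the core of compound 1 is not broken down here.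

The compound not yet measured is compound 4, `Fc1ccc2c(-c3nnc(N[C@@H](c4cccnc4F)C4CC4)o3)c[nH]c2n1`. Among the measured compounds shown here, it differs from compound 3 by fluoro in place of hydrogen on an aromatic carbon, which is the same change as the one made from compound 1 to compound 2: the group that enters, the group that leaves and the surroundings of the place are described in the same words. For the measured compounds named here, that earlier step is the only guide available, and it is a single observation on a different core. On that basis the step from compound 3 to compound 4 is expected to be a 1.8-fold lower number from compound 3 to compound 4 (0.24 log units; within the scatter), a little smaller than the earlier one and starting from an already low number. Compound 4 is therefore estimated at 12 mL.min-1.g-1, with a plausible span from 5 mL.min-1.g-1 to 30 mL.min-1.g-1.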

Compound 4, intrinsic clearance in microsomes: < 14 mL.min-1.g-1
Compound 4: only a limit was reported; the forecaster's own chance of this, stated with the estimate: 10%; the middle value lies beyond the limit too.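

In this assay compound 4 gives < 14 mL.min-1.g-1, which is a limit of the assay and not an exact number. Fluoro in place of hydrogen on an aromatic carbon therefore comes with an at least 1.5-fold lower number from compound 3 to compound 4 (0.17 log units; that floor lies within the scatter), so the change again goes with a lower number on a second core, although the printed figure is only a floor for the step. This supports the direction of the change on these two pairs of compounds, but it does not show that the change has the same size on both cores, and two pairs are too few to make a rule for the series: the same change on two cores in this assay, a 2.4-fold lower number (0.39 log units; beyond the scatter) from compound 1 to compound 2 and an at least 1.5-fold lower number (0.17 log units; that floor lies within the scatter) from compound 3 to compound 4; the limit leaves it open whether they differ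

The compounds shown leave open whether the lower number is particular to fluoro or would also appear with another group on the same aromatic carbon, such as chloro, methyl or a nitrile. They also leave open what the exact number for compound 4 is, and so how much of the room under the earlier value the fluoro step really uses.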